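From a methylphenyl to a methoxyphenyl neighbour

The source may hold more compounds than are shown below. What is called first, only, known or untested is meant among the compounds shown, and "the series" means these compounds.

Compound 1 `Cc1ccc(NC2=CC(=O)c3c(nc4n3[C@H]3OC[C@@H](O)[C@H]3OC4)C2=O)cc1` was examined in a functional assay on ECa-109 cells for inhibition, with ECa-109 cell line (Homo sapiens) as the target, read by sulforhodamine B assay; on this read-out lower numbers stand for stronger inhibition and higher numbers for weaker inhibition. In this assay compound 1 gives only > 4000 nM, which is a limit of the assay and not a measured number. Compound 1 thus sits at the limit of > 4000 nM in this assay, at which 1 of the 2 values shown sits. Compound 2 `Cc1ccc(NC2=CC(=O)c3nc4n(c3C2=O)[C@H]2OC[C@@H](O)[C@H]2OC4)cc1C` carries the same kind of anilino group on a closely related core, and in this assay compound 2 gives 2820 nM. Among the compounds with values here, no step between these two measured compounds is given, so their values stand only side by side.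

Compound 3 `COc1cccc(NC2=CC(=O)c3c(nc4n3[C@H]3OC[C@@H](O)[C@H]3OC4)C2=O)c1` awaits measurement. It differs from compound 1 in one place: 3-methoxyphenyl in place of 4-methylphenyl on an amine nitrogen. Compound 1 offers no number to move from, only a limit, so nothing shown points in either direction. For compound 3 the expected step that the limit leaves unreadable from compound 1 to compound 3 is none beyond the usual scatter. Compound 3 is therefore estimated at 4500 nM, within a range from 1500 nM to 12000 nM, with a real chance that the assay again reports only a limit.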

Compound 3, half-maximal inhibitory concentration: 3340 nM
The estimate for compound 3 lay 1.3-fold (0.13 log units) above the measured number; the measured number falls inside the stated range.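

Placing 3-methoxyphenyl on the amine nitrogen gives this series a measured number where the core of compound 1 offered none, and in this assay compound 3 gives 3340 nM. Compound 1 still reads only as a limit of the assay: the limit of > 4000 nM in this assay, at which 1 of the 3 values shown sits. The change amounts to an at least 1.1-fold lower number from compound 1 to compound 3 (0.07 log units; that floor lies within the scatter), so the swap shows no gain that can be told apart from the scatter, although the true step may be larger.

As far as these compounds go, the size of that step stays unknown as long as compound 1 has no number of its own, and the swap alters both the group and its place on the ring. A 4-methoxyphenyl group on the same nitrogen would separate those two changes, while a 4-chlorophenyl group or an aniline bearing a carboxylic acid would test quite different groups there.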